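The source may report more compounds than this note shows. Statements on the series, on what has been measured and on what is new or still open speak of the compounds shown alone.

Measured compounds in an assay for inhibition of alkaline phosphatase, tissue-nonspecific isozyme (Homo sapiens), read by spectrophotometry, with stated times of 10 min and 20 min; a higher number here means a weaker inhibitor, a lower number a stronger inhibitor:
compound 1 `O=C1/C(=C/c2ccccc2)NS(=O)(=O)c2ccccc21` gives 660 nM;
compound 2 `COc1cccc(/C=C2\NS(=O)(=O)c3ccccc3C2=O)c1` gives only a limit, > 200000 nM;
compound 3 `COc1ccc(/C=C2\NS(=O)(=O)c3ccccc3C2=O)cc1` gives 4040 nM.

Compound 1 stands lowest of the two numbers shown, with compound 3 the nearest to it. The step to compound 2 sits at the limit of > 200000 nM in this assay, at which 1 of the 3 values shown sits, and is therefore known only as a minimum. The unmeasured compound 4 `O=C1/C(=C/c2ccccc2Br)NS(=O)(=O)c2ccccc21` differs from compound 1 in one place: bromo in place of hydrogen on an aromatic carbon, that is, phenyl to 2-bromophenyl.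

Within the data shown here, two measured steps bear on a change of this kind, both adding a group to the same phenyl ring of the shared core, though neither adds bromo and neither puts the group at the place where compound 4 carries it. One is a 6.1-fold higher number from compound 1 to compound 3 (0.79 log units; beyond the scatter), a modest loss. The other is an at least 300-fold higher number from compound 1 to compound 2 (2.48 log units; beyond the scatter), a large loss. Both steps point the same way, so a higher number in this assay is expected for compound 4, most likely nearer the modest step than the large one, since the entering group is a single bromine rather than methoxy and its place is a different one. The expected step is a 3.0-fold higher number from compound 1 to compound 4 (0.48 log units; beyond the scatter). Compound 4 is therefore estimated at 2000 nM, in the range 400 nM to 20000 nM.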

Compound 4, half-maximal inhibitory concentration: > 200000 nM
Compound 4: only a limit was reported (the forecaster's own chance of this, stated with the estimate: 10%); middle value at least 100-fold (2.00 log units) away from the limit.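

In this assay, bromo in place of hydrogen, on an aromatic carbon ortho to a large group, gives an at least 300-fold higher number from compound 1 to compound 4 (2.48 log units; beyond the scatter), a large step for an entering group of one heavy atom. Until now the only large loss on this phenyl ring came with methoxy, and compound 3 showed that methoxy could also cost only a modest amount, so the new step shows that a large loss is not confined to methoxy and that this second kind of group, at this place, can produce one as well. Among these compounds, compound 4 is known only by a limit, so its step is a minimum, and compound 2 is the one other compound held at that same limit: the limit of > 200000 nM in this assay, at which 2 of the 4 values shown sit.

What fluoro, methyl, hydroxy or an amine would do at this same place stays open, so the compounds shown cannot tell whether the loss belongs to bromo itself or to any group put there. Going by these compounds, how compound 2 and compound 4 rank against each other also stays open, and so does what bromo would do elsewhere on the ring.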